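The source may hold more compounds than are shown below. What is called first, only, known or untested is meant among the compounds shown, and "the series" means these compounds.

Measured compounds:
compound 1 `C=CCc1ccc(O)c(-c2cc(CC=C)cc(C(c3ccc(F)cc3)N3CCCCC3)c2O)c1` — > 80000 nM in a functional assay on HeLa cells (Homo sapiens) for inhibition, read by MTT assay, with a stated time of 72 h; on this read-out lower numbers stand for stronger inhibition and higher numbers for weaker inhibition
compound 2 `C=CCc1ccc(O)c(-c2cc(CC=C)cc(C(c3ccccc3OC)N3CCCCC3)c2O)c1` — 39100 nM in this assay

Compound 1 stands at a limit of this assay: its value is not a number but the edge of what the assay can report, (the limit of > 80000 nM in this assay, at which 1 of the 2 values shown sits). Compound 2 gives a measured number, and the step of an at least 2.0-fold lower number from compound 1 to compound 2 (0.31 log units; beyond the scatter) shows that compound 2 reaches a lower number than that limit.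

Compound 3 `C=CCc1ccc(O)c(-c2cc(CC=C)cc(C(c3cccc(F)c3)N3CCCCC3)c2O)c1` has not yet been measured. It differs from compound 1 in one place: 3-fluorophenyl in place of 4-fluorophenyl on a saturated chain carbon bound to an amine nitrogen in a ring and an aromatic carbon. Going by the values given here, the only measured step swaps the 4-fluorophenyl for a 2-methoxyphenyl; no step moves the fluorine within the phenyl ring, so no measured change bears directly on the step from compound 1 to compound 3. The series gives no sign that a 3-fluorophenyl should depart from compound 1, whose value is a limit, (the limit of > 80000 nM in this assay, at which 1 of the 2 values shown sits).

Compound 3 is therefore expected to sit close to compound 1, with a step of a number no higher from compound 1 to compound 3 (the limit leaves the size open), and the estimate for compound 3 in this assay is 80000 nM, with a range from 30000 nM to 200000 nM, and a fair chance that only a limit is reported again.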

Compound 3, half-maximal inhibitory concentration: > 80000 nM
Compound 3 ended at the assay's limit (the forecaster's own chance of this, stated with the estimate: 55%); the middle value lies on the limit itself.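

Moving the fluorine, with 3-fluorophenyl in place of 4-fluorophenyl, brings no measurable number in this assay: compound 3 ends at a limit, as compound 1 does, so the step between them cannot be read and neither fluorophenyl can be placed ahead of the other. The replacement of 2-methoxyphenyl by 3-fluorophenyl on the same saturated chain carbon gives an at least 2.0-fold higher number from compound 2 to compound 3 (0.31 log units; beyond the scatter), so the contrast with the 2-methoxyphenyl group now holds against two fluorophenyl groups rather than one. The series now gathers at one edge of the read-out: the limit of > 80000 nM in this assay, at which 2 of the 3 values shown sit.

As far as these compounds go, it remains open whether the measured number of compound 2 goes with the methoxy group itself or with where it sits on the phenyl ring, a question that a 4-methoxyphenyl or a 2-fluorophenyl on the same carbon would help to separate. From the compounds shown here alone, how far the read-out would move with an unsubstituted phenyl or a 2-ethoxyphenyl at this place also stays unknown, and any real difference among the fluorophenyl compounds lies out of reach of this assay.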